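Swapping the acyl group on a trimethoxyphenyl amide

The compounds below may be only part of what the source reports. "The series", "measured", "known", "first", "only" and "open" are said of these compounds alone.

Measured so far:
- compound 1 `COc1ccc(CN(C(=O)C2CC2)c2cc(OC)c(OC)c(OC)c2)cc1O`: 49 nM
- compound 2 `C=C(C)C(=O)N(Cc1ccc(OC)c(O)c1)c1cc(OC)c(OC)c(OC)c1`: 200 nM

In a functional assay on HCT-116 cells (Homo sapiens) for inhibition, read by MTT assay, with a stated time of 48 h (on this read-out higher numbers stand for weaker inhibition and lower numbers for stronger inhibition), compound 2 gives the higher of the two numbers; compound 1 sits lower by a 4.1-fold higher number from compound 1 to compound 2 (0.61 log units; beyond the scatter). Compound 3 `COc1ccc(CN(C(=O)C=C(C)C)c2cc(OC)c(OC)c(OC)c2)cc1O` is the next step: 2-methylprop-1-en-1-yl in place of 1-methylethenyl on a carbonyl carbon. Among the measured compounds shown here, the only measured step touching this carbonyl carbon is a 4.1-fold higher number from compound 1 to compound 2 (0.61 log units; beyond the scatter), which shows that changing the acyl group can move the number beyond the scatter. Moving one carbon in an already unsaturated group is a smaller change, so compound 3 is expected to shift by a 1.3-fold higher number from compound 2 to compound 3 (0.11 log units; within the scatter), within the scatter. Compound 3 is estimated at 260 nM, in the range 80 nM to 850 nM.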

Compound 3, half-maximal inhibitory concentration: 290 nM
Compound 3: middle estimate off by 1.1-fold (0.05 log units), on the low side; the range from low to high includes it.
By their numbers in this assay, from the lowest: compound 1; then compounds 2 and 3 (each within the scatter of the next).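

In this assay, a 1.5-fold higher number from compound 2 to compound 3 (0.16 log units; within the scatter) separates the two acyl groups with a double bond by no more than ordinary assay variation, so moving from 1-methylethenyl to 2-methylprop-1-en-1-yl gives no readable change. The step against cyclopropyl is larger, at a 5.9-fold higher number from compound 1 to compound 3 (0.77 log units; beyond the scatter), so both groups with a double bond now stand apart from compound 1 on this carbonyl carbon. Nothing measured here explains these differences. The compounds shown leave open how a saturated chain such as isobutyl, a larger ring such as cyclobutyl, or an acyl group carrying an amine would compare with cyclopropyl.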